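From Carboxy to Methoxy in a Growth Inhibition Test

The compounds below may be only part of what the source reports. "The series", "measured", "known", "first", "only" and "open" are said of these compounds alone.

In a functional assay on MCF7 cells (Homo sapiens) for inhibition, with a stated time of 48 h (on this read-out higher numbers stand for weaker inhibition of growth and lower numbers for stronger inhibition of growth), compound 1 `N#Cc1cnn(-c2ccc(C(=O)O)cc2)c1N` stands at "not determined" (no result reported). Compound 2 `Nc1ncnc2c1cnn2-c1ccc(C(=O)O)cc1` has no single number to start from, and it stands at "not determined" (no result reported). Compound 3 `CC(=O)OC[C@H]1O[C@@H](Nc2ncnc3c2cnn3-c2ccc(C(=O)O)cc2)[C@H](OC(C)=O)[C@@H](OC(C)=O)[C@@H]1OC(C)=O` gives > 150000 nM, which is a limit of the assay and not a number. The next structure is compound 4 `COc1ccc(-n2ncc3c(N)ncnc32)cc1`. The change methoxy in place of carboxy on an aromatic carbon is methoxy in place of carboxy on an aromatic carbon, para to a large group. Going by the values given here, no measured step can serve as a guide, so any forecast is tentative. In this assay, a moderate move towards stronger inhibition of growth is expected. For compound 4 the estimated value is 40000 nM, with an expected range from 8000 nM to 150000 nM.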

Compound 4, concentration for 50% growth inhibition: > 150000 nM
Compound 4: no number, only a limit; the forecaster's own chance of this, stated with the estimate: 30%; middle value at least 3.7-fold (0.57 log units) away from the limit.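

Going by these compounds alone, compound 2 has no single number, so no step from it to compound 4 can be read. Compound 4 gives > 150000 nM, which is a limit and not a number. On these data alone, whether methoxy in place of carboxy changes the result in this assay stays open.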